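Removing a chloro next to trifluoromethyl: compound 4 expected

The compounds below may be only part of what the source reports. "The series", "measured", "known", "first", "only" and "open" are said of these compounds alone.

Three compounds share one core and differ in small groups. Compound 2 `COc1cc(Cl)cc(-c2nn(-c3cccc(NC(=O)Nc4ccc(Cl)c(C(F)(F)F)c4)c3)cc2-c2ccncc2)c1` gives -56% in a functional assay on OVCAR-3 cells (Homo sapiens) for inhibition, read by sulforhodamine B assay, with a stated time of 48 h, tested at 100 uM (on this read-out lower numbers stand for a stronger effect and higher numbers for a weaker effect at the one concentration tested), the lowest of the three numbers; compound 1 `O=C(Nc1cccc(-n2cc(-c3ccncc3)c(-c3cc(O)cc(Cl)c3)n2)c1)Nc1ccc(Cl)c(Cl)c1` gives -20% and compound 3 `COc1cc(Cl)cc(-c2nn(-c3cccc(NC(=O)Nc4ccc(Cl)c(Cl)c4)c3)cc2-c2ccncc2)c1` gives -4%. Compound 4 `COc1cc(Cl)cc(-c2nn(-c3cccc(NC(=O)Nc4cccc(C(F)(F)F)c4)c3)cc2-c2ccncc2)c1` is not yet measured. It differs from compound 2 by hydrogen in place of chloro on an aromatic carbon, on an aromatic carbon ortho to a trifluoromethyl group. Among the compounds with values here, no measured step shows this exact change. The step of a number 52 percentage points higher from compound 2 to compound 3 (beyond the scatter) touched the same ring and was large, while a number 16 percentage points higher from compound 1 to compound 3 (beyond the scatter) was modest elsewhere. A rise beyond the scatter is therefore expected, with compound 4 estimated at -30%, between -65% and 5%, meaning a step of a number 26 percentage points higher from compound 2 to compound 4 (beyond the scatter).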

Compound 4, a percentage reported as activity, at one concentration (the size of the read-out at that concentration, not a potency): -41%
Beside the measured number, compound 4's estimate is 11 percentage points above it; the measured number falls inside the stated range.
By their numbers in this assay, from the lowest: compound 2; then compound 4; then compound 1; then compound 3.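

In this assay, removing the chloro from the 4-chloro-3-(trifluoromethyl)phenyl group weakens the effect only modestly (with a number 15 percentage points higher from compound 2 to compound 4 (beyond the scatter)), so this chloro is not essential for a low number. The 3-(trifluoromethyl)phenyl group alone still outperforms the 3,4-dichlorophenyl group by a large margin (with a number 37 percentage points lower from compound 3 to compound 4 (beyond the scatter)), which singles out trifluoromethyl as the more valuable of the ring's groups in this comparison. From the compounds shown here alone, what an amine or a carboxylic acid would do in place of this chloro remains open. Nothing shown explains why either step has its size.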